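Fluoro to Chloro on a Shared Core: Estimating Compound 4

The source may hold more compounds than are shown below. What is called first, only, known or untested is meant among the compounds shown, and "the series" means these compounds.

Three compounds were measured in a functional assay on HCT-116 cells (Homo sapiens) for cytotoxicity, read by MTT assay, with a stated time of 48 h; on this read-out lower numbers stand for stronger inhibition and higher numbers for weaker inhibition:
compound 1 `CNC(=O)c1ccc(Sc2ccc(NC(=O)Nc3ccc(Cl)c(C(F)(F)F)c3)cc2)nc1`, 5290 nM;
compound 2 `CNC(=O)c1ccc(Sc2ccc(NC(=S)Nc3ccc(F)c(C(F)(F)F)c3)cc2)nc1`, 6370 nM;
compound 3 `CNC(=O)c1ccc(Sc2ccc(NC(=O)Nc3ccc(F)c(C(F)(F)F)c3)cc2)nc1`, 5800 nM.

Compound 3 and compound 1 differ in one place, (chloro in place of fluoro on an aromatic carbon), and the step is a 1.1-fold lower number from compound 3 to compound 1 (0.04 log units; within the scatter). Compound 2 and compound 3 differ in their cores; that difference is not broken down here, and their two values lie within the scatter of each other, so nothing can be said of an order between them. All three values sit close together.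

Compound 4 `CNC(=O)c1ccc(Sc2ccc(NC(=S)Nc3ccc(Cl)c(C(F)(F)F)c3)cc2)nc1` is not yet measured. It differs from compound 2 by chloro in place of fluoro on an aromatic carbon, the same change that was made from compound 3 to compound 1, with the same surroundings word for word. Because the measured instance gave only a 1.1-fold lower number from compound 3 to compound 1 (0.04 log units; within the scatter), compound 4 is expected to show a comparably small step, a 1.1-fold lower number from compound 2 to compound 4 (0.04 log units; within the scatter), in this assay. Compound 4 is therefore estimated at 5800 nM, with a range from 3000 nM to 11000 nM expected.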

Compound 4, half-maximal inhibitory concentration: 4900 nM
For compound 4 the middle estimate is 1.2-fold (0.07 log units) above the measured one, and the stated range covers the measured number.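

Carried to a second core, chloro in place of fluoro gives a 1.3-fold lower number from compound 2 to compound 4 (0.11 log units; within the scatter). The two steps do not differ, so across these two cores the change behaves alike in this assay: the same change on two cores in this assay, a 1.1-fold lower number (0.04 log units; within the scatter) from compound 3 to compound 1 and a 1.3-fold lower number (0.11 log units; within the scatter) from compound 2 to compound 4, 1.2-fold (0.07 log units) apart, within the scatter of two such steps

For the compounds shown here, both steps lie within the scatter, however, so the agreement shows only that the change produces no step beyond the scatter on these two cores; it does not show that a larger effect would carry from one core to another, nor that the same would hold on any further core.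

The compounds shown leave open whether another group in this place, such as a methyl, a methoxy or a nitrile, would give a number beyond the scatter of the chloro and fluoro compounds. They also leave open what an amine or a carboxylic acid in place of the trifluoromethyl group would give in this assay.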